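Replacing the bromine-bearing group of compound 2

The source may hold more compounds than are shown below. What is called first, only, known or untested is meant among the compounds shown, and "the series" means these compounds.

In a functional assay on L1210 cells (Mus musculus) for inhibition (a lower number here means a stronger inhibitor, a higher number a weaker inhibitor), compound 1 (`CC(C)CN(CC(=O)N(CC(C)C)NC(=O)OCc1ccccc1)NC(=O)CBr`) gives 6500 nM and compound 2 (`CC(C)CN(CC(=O)NN(Cc1ccccc1)c1cnccn1)NC(=O)CBr`) gives 24100 nM while compound 3 (`CC(C)CN(NC(=O)OCc1ccccc1)C(=O)CN(Cc1ccccc1)NC(=O)Cc1cccc(Br)c1`) gives 30000 nM on the same read-out. Compound 2 therefore sits level with compound 3 within the usual scatter, and compound 1 has a lower number than compound 2 by more than that scatter. Compound 4 (`CC(C)CN(CC(=O)NN(Cc1ccccc1)c1cnccn1)/N=C/c1cccc(B(O)O)c1`) differs from compound 2 in one place, on an amine nitrogen, and a group of 11 heavy atoms (7 carbon, 1 boron, 1 nitrogen, 2 oxygen; one six-membered aromatic ring of carbon only) in place of a group of 5 heavy atoms (2 carbon, 1 nitrogen, 1 oxygen, 1 bromine; no ring), on an amine nitrogen describes that change. Going by the values given here, no measured pair shows this change alone, so any forecast rests on thin evidence. Among the compounds with values here, compound 3, the only measured compound without the ((bromomethyl)carbonyl)amino group, stands at 30000 nM in this assay and so gives no sign of a gain. The expected outcome is no step beyond the scatter, an estimated 1.2-fold higher number from compound 2 to compound 4 (0.10 log units; within the scatter) in this assay with wide uncertainty around it. Compound 4 is estimated at 30000 nM with an expected range from 8000 nM to 100000 nM on this small set of data.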

Compound 4, half-maximal inhibitory concentration: > 80000 nM
Compound 4 gave a limit, no number; the forecaster's own chance of this, stated with the estimate: 20%; middle value at least 2.6-fold (0.42 log units) away from the limit.
By their numbers in this assay, from the lowest: compound 1; then compounds 2 and 3 (each within the scatter of the next). At a limit, above all of these: compound 4.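

In this assay, the change on the amine nitrogen of compound 2, from the ((bromomethyl)carbonyl)amino group to the larger group carrying boron and a six-membered aromatic ring, gives a loss of inhibition: an at least 3.3-fold higher number from compound 2 to compound 4 (0.52 log units; beyond the scatter). Going by these compounds alone, this is the first pair in the set that differs in one place, and it shows that the group on this nitrogen can change the read-out by more than the scatter. The read-out for compound 4 is a limit of the assay and not a number: the limit of > 80000 nM in this assay, at which 1 of the 4 values shown sits.

Going by these compounds, how far the loss extends past that limit stays open, as does whether it follows the departure of the bromine-bearing group or the arrival of the new one. A plain acetylamino group or a ((chloromethyl)carbonyl)amino group on the same nitrogen would help separate these two readings.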